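Chain extension from compound 3 to compound 4

This account rests on a few compounds, and the source may have more. Where it says the series, first, only, none or still open, it means among the compounds named here.

In a functional assay on SK-OV-3 cells (Homo sapiens) for cytotoxicity, read by MTT assay, with a stated time of 24 h (a lower number here means a stronger inhibitor, a higher number a weaker inhibitor), compound 1 (`CCCCCCCCCCCC(=O)Nc1nnc(S[C@@H]2O[C@H](COC(C)=O)[C@H](OC(C)=O)[C@H](OC(C)=O)[C@H]2OC(C)=O)s1`) gives "not active" (no number reported), and compound 2 (`CCCCCCCCCCCCCC(=O)Nc1nnc(S[C@@H]2O[C@H](COC(C)=O)[C@H](OC(C)=O)[C@H](OC(C)=O)[C@H]2OC(C)=O)s1`) gives "not active" (no number reported). Going by the values given here, compound 3 (`CCCCCCCC(=O)Nc1nnc(S[C@@H]2O[C@H](CO)[C@H](O)[C@H](O)[C@H]2O)s1`) gives 56000 nM, the only number so far, so its standing cannot be ranked against a second value.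

Compound 4 (`CCCCCCCCCCCCCCCC(=O)Nc1nnc(S[C@@H]2O[C@H](CO)[C@H](O)[C@H](O)[C@H]2O)s1`) departs from compound 3 by octyl in place of hydrogen on a saturated chain carbon, seven bonds along the chain from a carbonyl carbon. Among the compounds with values here, no step between measured compounds is available to scale this change, so the expectation is tentative and rests on the single anchor, compound 3 at 56000 nM.

A modest gain in inhibition is expected, with a 2.2-fold lower number from compound 3 to compound 4 (0.35 log units; beyond the scatter) as the estimated step toward a lower number. A result without a number also remains possible, as seen for compound 2 at "not active" (no number reported).

The estimate for compound 4 is 25000 nM, with an expected range from 7000 nM to 90000 nM.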

Compound 4, half-maximal inhibitory concentration: "not active" (no number reported)
Compound 4: no number reported; no gap can be computed for the estimate.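

In this assay, going by these compounds alone, compound 4 carries no number, and no step from compound 3 to compound 4 can be read. No measured evidence bears on this result. The compounds shown leave open how the reading changes for chain lengths between those of compound 3 and compound 4.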